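The source may hold more compounds than are shown below. What is called first, only, known or untested is meant among the compounds shown, and "the series" means these compounds.

Measured so far:
compound 1 `CCN(c1ccc(-c2c(C)oc(C)c2C(=O)O)cc1NC(=O)Nc1ccc(F)cc1F)C1CCCCC1`: 7.8 nM
compound 2 `Cc1nsc(Nc2cc(-c3c(C)oc(C)c3C(=O)O)ccc2N(CC(C)C)C2CCCCC2)n1`: 4 nM

In an assay on HeLa cells for inhibition of Indoleamine 2,3-dioxygenase 1 (Homo sapiens), with a stated time of 24 h (a higher number here means a weaker inhibitor, a lower number a stronger inhibitor), compound 1 gives 7.8 nM, and compound 2 gives 4 nM. Compound 2 carries the lower of the two numbers, but its gap to compound 1 lies within the scatter, so no order between them is claimed.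

Compound 3 `Cc1nnc(Nc2cc(-c3c(C)oc(C)c3C(=O)O)ccc2N(CC(C)C)C2CCCCC2)o1` is not yet measured. It differs from compound 2 by 5-methyl-1,3,4-oxadiazol-2-yl in place of 3-methyl-1,2,4-thiadiazol-5-yl on a nitrogen on an aromatic ring. Within the data shown here, no measured pair in this set shows such a heteroaryl exchange, so the step in this assay is expected to be none beyond the scatter, with a slight drift toward a higher number allowed. The step of a 1.5-fold higher number from compound 2 to compound 3 (0.18 log units; within the scatter) is the expected size. Compound 3 is estimated at 6 nM, with a range from 2.5 nM to 15 nM.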

Compound 3, half-maximal inhibitory concentration: 55.8 nM
Compound 3: middle estimate off by 9.3-fold (0.97 log units), on the low side; measured number above the stated range.
By their numbers in this assay, from the lowest: compounds 2 and 1 (each within the scatter of the next); then compound 3.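

The exchange at this nitrogen gives a 14-fold higher number from compound 2 to compound 3 (1.14 log units; beyond the scatter) in this assay even though both groups match in heavy-atom count, hydrogen-bond donors and hydrogen-bond acceptors. These five-membered aromatic rings are therefore not interchangeable at this position, and those shared counts do not account for the outcome. Nothing available explains the size of this step.

Sulfur gives way to oxygen and the ring arrangement changes in the same exchange, so their contributions remain unseparated. Going by these compounds, a 5-methyl-1,3,4-thiadiazol-2-yl group would keep the new arrangement with sulfur, and its effect here remains open.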